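Working notes: changing the aryl group in the series

The source may hold more compounds than are shown below. What is called first, only, known or untested is meant among the compounds shown, and "the series" means these compounds.

In a functional assay on HepG2 cells (Homo sapiens) for cytotoxicity, read by MTT assay, with a stated time of 48 h (a higher number here means a weaker inhibitor, a lower number a stronger inhibitor), compound 1 `O=C(CSc1nnc(-c2ccncc2)o1)N/N=C/c1ccc([N+](=O)[O-])cc1` gives 17900 nM and compound 2 `O=C(CSc1nnc(-c2ccncc2)o1)N/N=C/c1cc(Br)cc(Br)c1O` gives 6540 nM. For the measured compounds named here, compound 2 therefore holds the lower of the two numbers so far. Compound 3 `O=C(CSc1nnc(-c2ccncc2)o1)N/N=C/c1ccc(Cl)cc1Cl` keeps the shared core and carries 2,4-dichlorophenyl in place of 3,5-dibromo-2-hydroxyphenyl on a carbon with a double bond to nitrogen. Going by the values given here, the only measured step bearing on this change is a 2.7-fold lower number from compound 1 to compound 2 (0.44 log units; beyond the scatter), which is modest and introduced the group that now leaves. Among the compounds with values here, no measured compound carries 2,4-dichlorophenyl, so the expectation rests on that single step. A similarly modest step toward a higher number is therefore expected in this assay. The estimated step is a 2.1-fold higher number from compound 2 to compound 3 (0.33 log units; beyond the scatter). The expected value for compound 3 is 14000 nM, with an estimated range of 5000 nM to 35000 nM.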

Compound 3, half-maximal inhibitory concentration: 18600 nM
The estimate for compound 3 lay 1.3-fold (0.12 log units) below the measured number; low and high end bracket the measured number.
By their numbers in this assay, from the lowest: compound 2; then compounds 1 and 3 (each within the scatter of the next).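

In this assay, 2,4-dichlorophenyl in place of 3,5-dibromo-2-hydroxyphenyl on a carbon with a double bond to nitrogen gives a clear reversal (a 2.8-fold higher number from compound 2 to compound 3 (0.45 log units; beyond the scatter)), so the lower number of compound 2 does not carry over to a second halogenated aryl group. 2,4-Dichlorophenyl in place of 4-nitrophenyl gives no readable change (a 1.0-fold higher number from compound 1 to compound 3 (0.02 log units; within the scatter)), which leaves compound 2 alone apart from the other two at this position. For the compounds shown here, nothing measured so far accounts for this difference.

The compounds shown do not separate the hydroxy group from the two bromines within 3,5-dibromo-2-hydroxyphenyl. From the compounds shown here alone, how an aryl group bearing an amine or a carboxylic acid at this place would read in this assay also remains open.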